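Acetyl to 2-aminoethyl: working notes on the series

The compounds below may be only part of what the source reports. "The series", "measured", "known", "first", "only" and "open" are said of these compounds alone.

In a functional assay for inhibition, read by spectrophotometry, with a stated time of 60 min (a lower number here means a stronger inhibitor, a higher number a weaker inhibitor), compound 1 (`CC(=O)N1CCN(c2ccc3nnc(-c4cccc(C)c4)n3n2)CC1`) gives 28.6 ug/mL and compound 2 (`Cc1cccc(-c2nnc3ccc(N4CCN(C(=O)OC(C)(C)C)C(Cc5ccccc5)C4)nn23)c1`) gives 15.8 ug/mL with the two values within the scatter of each other. For the measured compounds named here, compound 1 therefore stands level with the only other measured compound. Compound 3 (`Cc1cccc(-c2nnc3ccc(N4CCN(CCN)CC4)nn23)c1`) has 2-aminoethyl in place of acetyl on an amine nitrogen in a ring. Going by the values given here, no measured step bears on this change, so in this assay no step beyond the scatter is expected in either direction. The expected size is a 1.2-fold lower number from compound 1 to compound 3 (0.08 log units; within the scatter) on this estimate. The expected value for compound 3 is 24 ug/mL within an estimated range of 9 ug/mL to 60 ug/mL for now.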

Compound 3, half-maximal inhibitory concentration: 25.4 ug/mL
Compound 3: the middle estimate sits 1.1-fold (0.02 log units) below what was measured; the range from low to high includes it.
By their numbers in this assay, from the lowest: compounds 2, 3 and 1 (each within the scatter of the next).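

In this assay the first step measured at this position (a 1.1-fold lower number from compound 1 to compound 3 (0.05 log units; within the scatter)) shows that 2-aminoethyl can replace acetyl on this amine nitrogen in a ring without a step beyond the scatter. The exchange removes the double bond outside aromatic rings and brings in a hydrogen-bond donor, and neither difference moves the number beyond the scatter here. No measurement on hand offers an explanation for this result.

Still open, as far as these compounds go, is whether a longer chain, such as 3-aminopropyl, would also stay within the scatter of compound 1. From the compounds shown here alone, a carboxylic acid at the end of the chain is equally open.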